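This account rests on a few compounds, and the source may have more. Where it says the series, first, only, none or still open, it means among the compounds named here.

Compound 1 `O=C(CCC(=O)OCCCCCCSc1ccc([N+](=O)[O-])c2nonc12)Nc1ccccc1Cl`: 5850 nM
Compound 2 `Cc1ccccc1NC(=O)CCC(=O)OCCCCCCSc1ccc([N+](=O)[O-])c2nonc12`: 9490 nM
Compound 3 `O=C(CCC(=O)OCCCCCCSc1ccc([N+](=O)[O-])c2nonc12)Nc1cccc(Cl)c1`: 6930 nM

These values come from an ADME assay on L02 cells (Homo sapiens) for cytotoxicity, read by MTT assay, with a stated time of 72 h (a lower number here means a stronger inhibitor, a higher number a weaker inhibitor), and compound 2, at 9490 nM, lies within the scatter of both other compounds. Compound 4 `O=C(CCC(=O)OCCCCCCSc1ccc([N+](=O)[O-])c2nonc12)Nc1ccc(Br)cc1` awaits measurement. It differs from compound 2 by 4-bromophenyl in place of 2-methylphenyl on an amide-type nitrogen, with 4-bromophenyl in place of 2-methylphenyl on an amide-type nitrogen. Compound 3 offers the closest guide: a 1.4-fold lower number from compound 2 to compound 3 (0.14 log units; within the scatter), replacing the same 2-methylphenyl with 3-chlorophenyl. The other two steps, a 1.6-fold higher number from compound 1 to compound 2 (0.21 log units; within the scatter) and a 1.2-fold higher number from compound 1 to compound 3 (0.07 log units; within the scatter), are similarly small. Among the measured compounds shown here, no compound bearing bromine has been measured. No step beyond the scatter is therefore expected in this assay, and the expected change is a 1.4-fold lower number from compound 2 to compound 4 (0.13 log units; within the scatter). For compound 4 the estimate is 7000 nM, with an expected range from 3500 nM to 14000 nM.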

Compound 4, half-maximal inhibitory concentration: 4330 nM
The estimate for compound 4 lay 1.6-fold (0.21 log units) above the measured number; the range from low to high includes it.
By their numbers in this assay, from the lowest: compounds 4, 1, 3 and 2 (each within the scatter of the next, the first and the last beyond it).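

In this assay, replacing 2-methylphenyl with 4-bromophenyl on the amide-type nitrogen gives a 2.2-fold lower number from compound 2 to compound 4 (0.34 log units; beyond the scatter), the only step among these compounds beyond the scatter, and a modest one. The other two steps, a 1.6-fold lower number from compound 3 to compound 4 (0.20 log units; within the scatter) and a 1.4-fold lower number from compound 1 to compound 4 (0.13 log units; within the scatter), stay within it, so compound 4 separates from compound 2 alone. No measured evidence bears on this difference. The compounds shown leave open how an amine or a carboxylic acid on that phenyl ring, or a longer chain in the shared core, would read here.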